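This account rests on a few compounds, and the source may have more. Where it says the series, first, only, none or still open, it means among the compounds named here.

Measured compounds in a functional assay on cells for antagonist activity at prostaglandin E2 receptor EP1 subtype (Rattus norvegicus), read by fluorescence and calcium flux, with a stated time of 60 s; on this read-out higher numbers stand for weaker inhibition and lower numbers for stronger inhibition:
- compound 1 `O=C(O)c1cccc(Cc2c(-c3ccccc3)nn3cc(C4CC4)ccc23)n1`, which gives 190 nM
- compound 2 `CS(=O)(=O)c1ccc2c(Cc3cccc(C(=O)O)n3)c(-c3ccccc3)nn2c1`, which gives 5400 nM
- compound 3 `O=C(O)c1cccc(Cc2c(-c3cccc(Cl)c3)nn3cc(Cl)ccc23)n1`, which gives 480 nM

Compound 3 holds the second highest of the three numbers. Compound 1 lies nearest to it with a lower number, and compound 2 lies furthest with a higher one; both gaps are beyond the scatter.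

Compound 4 `O=C(O)c1cccc(Cc2c(-c3ccsc3)nn3cc(Cl)ccc23)n1` differs from compound 3 in one place: thiophen-3-yl in place of 3-chlorophenyl on an aromatic carbon.

Going by the values given here, the only measured single step, a 28-fold higher number from compound 1 to compound 2 (1.45 log units; beyond the scatter), concerns a different position of the shared core and therefore does not bear directly on this change. Compound 1 and compound 3 differ at two places at once, one of them the aryl group on the five-membered ring, so their values cannot be split between the two changes. Among the compounds with values here, no measured pair isolates the aryl group on the five-membered ring.

Within the data shown here, with no step that bears on it, compound 4 is expected to stay near compound 3, with a 1.3-fold higher number from compound 3 to compound 4 (0.10 log units; within the scatter) as the estimated step, and with a wide margin in either direction. The estimate for compound 4 is 600 nM, with a range from 200 nM to 1800 nM.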

Compound 4, half-maximal inhibitory concentration: 110 nM
Compound 4: middle estimate off by 5.5-fold (0.74 log units), on the high side; measured number below the stated range.
By their numbers in this assay, from the lowest: compounds 4 and 1 (each within the scatter of the next); then compound 3; then compound 2.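

In this assay, the aryl group on the five-membered ring proves to be a position where a single change moves the number: thiophen-3-yl in place of 3-chlorophenyl gives a 4.4-fold lower number from compound 3 to compound 4 (0.64 log units; beyond the scatter) with the rest of the structure unchanged. Going by these compounds alone, the earlier compounds could not show this, as the only pair differing at this position also differed elsewhere on the shared core. The new step shows that a six-membered aromatic ring of carbon only can give way here to a five-membered aromatic ring with one hetero atom without any loss in this read-out, although no measurement shown gives a reason for the lower number.

The compounds shown do not separate the loss of the chlorine from the change of ring, and a plain phenyl beside the chlorine on the shared core would be needed to tell these apart. Going by these compounds, it also remains open whether a furan-3-yl or pyridin-3-yl group would follow thiophen-3-yl, and whether the step would hold with cyclopropyl or methylsulfonyl in place of that chlorine.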